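The compounds below may be only part of what the source reports. "The series", "measured", "known", "first", "only" and "open" are said of these compounds alone.

Compound 1 `CC(C)(C)c1[nH]cnc1/C=c1\[nH]c(=O)/c(=C/c2cccc(Oc3ccc(F)cc3)c2)[nH]c1=O`: 4 nM
Compound 2 `O=c1[nH]/c(=C\c2ccc([N+](=O)[O-])o2)c(=O)[nH]/c1=C\c1cccc(Oc2ccc(F)cc2)c1`: > 1000 nM

In a functional assay on NCI-H460 cells (Homo sapiens) for cytotoxicity, read by MTT assay, with a stated time of 72 h (on this read-out lower numbers stand for stronger inhibition and higher numbers for weaker inhibition), compound 1 gives 4 nM. Compound 2 gives only a limit, > 1000 nM, and no number. It therefore stands at the limit of > 1000 nM in this assay, at which 1 of the 2 values shown sits.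

Compound 3 `O=c1[nH]/c(=C\c2nc3ccccc3[nH]2)c(=O)[nH]/c1=C\c1cccc(Oc2ccc(F)cc2)c1` differs from compound 2 as follows: 1H-benzimidazol-2-yl in place of 5-nitrofuran-2-yl on a double-bonded chain carbon bound to an aromatic carbon. In words, 1H-benzimidazol-2-yl takes the place of 5-nitrofuran-2-yl on a double-bonded chain carbon bound to an aromatic carbon.

Among the measured compounds shown here, one measured step bears on this change: an at least 250-fold higher number from compound 1 to compound 2 (2.39 log units; beyond the scatter). It is large and beyond the scatter, and it involves the same place. With 5-nitrofuran-2-yl gone, a lower number is expected in this assay, though not a full return to the level of compound 1, whose group is not restored. The size of the step is uncertain, and the assay may again report only a limit.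

The expected change is an estimated at least 3.3-fold lower number from compound 2 to compound 3 (0.52 log units; beyond the scatter). For compound 3 the estimated value is 300 nM, with an expected range of 30 nM to 3000 nM.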

Compound 3, half-maximal inhibitory concentration: > 1000 nM
Compound 3 was reported as a limit; the forecaster's own chance of this, stated with the estimate: 25%; at least 3.3-fold (0.52 log units) between middle value and limit.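

In this assay compound 3 gives > 1000 nM, which is a limit and not a number. Like 5-nitrofuran-2-yl, 1H-benzimidazol-2-yl on a double-bonded chain carbon bound to an aromatic carbon fails to match 5-(tert-butyl)-1H-imidazol-4-yl, with an at least 250-fold higher number from compound 1 to compound 3 (2.39 log units; beyond the scatter), so this large loss is not confined to the nitrofuran. The step between compound 2 and compound 3 cannot be read, because both stand at a limit: the limit of > 1000 nM in this assay, at which 2 of the 3 values shown sit.

Going by these compounds, how far either compound lies beyond that limit stays open, so the two groups cannot be ranked against each other. Also open, on these data alone, is whether the imidazole ring or the tert-butyl group is what matters for the value of compound 1, 4 nM, and what a plain 1H-imidazol-4-yl or an amine would give at this place.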